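The source may report more compounds than this note shows. Statements on the series, on what has been measured and on what is new or still open speak of the compounds shown alone.

In a functional assay on RKO cells (Homo sapiens) for cytotoxicity, read by resazurin assay, with a stated time of 72 h (a lower number here means a stronger inhibitor, a higher number a weaker inhibitor), compound 1 `Cc1cn(-c2csc(Nc3ccc(Br)cc3)n2)c(C)n1` gives 45000 nM, the lower of the two actual numbers in the series. Compound 3 `Cc1nc2ccccc2n1-c1csc(Nc2ccc(S(N)(=O)=O)cc2)n1` gives 95000 nM. Compound 2 `Cc1nccn1-c1csc(Nc2ccc(Br)cc2)n1` reads > 100000 nM, which is a limit and not a number. Compound 4 `COc1ccc(Nc2nc(-n3cc(C)nc3C)cs2)cc1` has methoxy in place of bromo on an aromatic carbon, para to a large group: methoxy in place of bromo on an aromatic carbon. Within the data shown here, the only measured step, an at least 2.2-fold higher number from compound 1 to compound 2 (0.34 log units; beyond the scatter), is hydrogen in place of methyl at a different place, so it bears only indirectly and no measured step covers this exchange. No step beyond the scatter is therefore expected in this assay. The expected change is a 1.3-fold higher number from compound 1 to compound 4 (0.12 log units; within the scatter). Compound 4 is estimated at 60000 nM, within an expected range of 25000 nM to 100000 nM.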

Compound 4, half-maximal inhibitory concentration: > 100000 nM
Compound 4 gave a limit, no number; the forecaster's own chance of this, stated with the estimate: 25%; at least 1.6-fold (0.22 log units) between middle value and limit.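

In this assay, the earlier step changed only hydrogen for methyl elsewhere, whereas this step shows that the group on the six-membered aromatic ring, para to a large group, also affects the read-out (an at least 2.2-fold higher number from compound 1 to compound 4 (0.34 log units; beyond the scatter)). Compound 4 gives > 100000 nM, which is a limit and not a number. The true size of this step therefore stays unresolved, with compound 4 at that limit: the limit of > 100000 nM in this assay, at which 2 of the 4 values shown sit.

As far as these compounds go, whether chloro, an amine or a carboxylic acid at this place would match bromo or fall further remains open.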